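Solubility across amine-linked analogues of the shared core

The compounds below may be only part of what the source reports. "The series", "measured", "known", "first", "only" and "open" are said of these compounds alone.

Measured compounds:
compound 1 `Cc1cc(NCc2ncc[nH]2)n2nc(C)c(-c3ccccc3)c2n1` — < 5000 nM
compound 2 `Cc1cc(NCC2CCCCN2)n2nc(C)c(-c3ccccc3)c2n1` — 189000 nM
compound 3 `CCN1CCCC1CNc1cc(C)nc2c(-c3ccccc3)c(C)nn12` — 172000 nM

In a physicochemical assay for solubility, read by HPLC, using the shake flask method, measured as kinetic solubility, with a stated time of 2 h, at pH 7.4 (on this read-out higher numbers stand for higher solubility and lower numbers for lower solubility), compound 3 stands lowest of the two numbers given, with compound 2 nearest and a 1.1-fold lower number from compound 2 to compound 3 (0.04 log units; within the scatter). For compound 1 the read-out is a limit of the assay, (the limit of < 5000 nM in this assay, at which 1 of the 3 values shown sits), not a number.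

Compound 4 `Cc1cc(NCc2ccc(F)cn2)n2nc(C)c(-c3ccccc3)c2n1` differs from compound 3 in one place: 5-fluoropyridin-2-yl in place of 1-ethylpyrrolidin-2-yl on a saturated chain carbon bound to a nitrogen on an aromatic ring. For the measured compounds named here, no measured step covers this exact change. The nearest are an at least 34-fold higher number from compound 1 to compound 3 (1.53 log units; beyond the scatter) and an at least 37-fold higher number from compound 1 to compound 2 (1.57 log units; beyond the scatter), both of which run from a saturated chain carbon carrying a five-membered aromatic ring to one carrying a saturated ring containing nitrogen. The change to compound 4 reverses that direction, since a six-membered aromatic ring enters where the five-membered non-aromatic ring leaves. A large downward step in this assay is therefore expected, with compound 4 plausibly reporting only a limit, as compound 1 did.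

For compound 4 the expected step is a 34-fold lower number from compound 3 to compound 4 (1.54 log units; beyond the scatter). Compound 4 is estimated at 5000 nM, with a range from 1000 nM to 25000 nM.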

Compound 4, solubility: < 5000 nM
Compound 4 gave a limit, no number; the forecaster's own chance of this, stated with the estimate: 50%; the middle value lies on the limit itself.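

In this assay the low end of the series does not depend on 1H-imidazol-2-yl: 5-fluoropyridin-2-yl on the same saturated chain carbon gives an at least 34-fold lower number from compound 3 to compound 4 (1.53 log units; beyond the scatter) and an at least 37-fold lower number from compound 2 to compound 4 (1.57 log units; beyond the scatter). Compound 1 and compound 4, the two compounds with an aromatic ring at this place, both give a limit and not a number, while no compound shown goes against this split from the two with saturated nitrogen rings: the limit of < 5000 nM in this assay, at which 2 of the 4 values shown sit. The step between compound 1 and compound 4 cannot be read, so the two aromatic groups stay unordered.

Open, as far as these compounds go, is whether the nitrogen or the saturated ring carries the change: cyclohexyl, or an open-chain dimethylamino group, on the same carbon would separate the two. Also open, from the compounds shown here alone, is whether an aromatic ring bearing an aminomethyl group would leave the limit.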